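From 3,4-Dihydroxyphenyl to 3,4-Dinitrophenyl in Compound 4

The source may report more compounds than this note shows. Statements on the series, on what has been measured and on what is new or still open speak of the compounds shown alone.

Compound 1, `O=C(NCCNS(=O)(=O)c1ccc(-c2ccccc2Oc2ccc(O)c(O)c2)s1)Nc1cc(Cl)cc(Cl)c1`: 10400 nM
Compound 2, `O=C(Nc1cccc([N+](=O)[O-])c1)N1CCN(S(=O)(=O)c2sccc2-c2ccccc2Oc2ccc(O)c(O)c2)CC1`: 4500 nM
Compound 3, `Nc1ccc(Oc2ccccc2-c2ccc(S(=O)(=O)NCCNC(=O)Nc3ccc(Cl)cc3)s2)cc1`: a limit, > 50000 nM

All three were tested in a functional assay on HL-60 cells (Homo sapiens) for inhibition, read by CCK-8 assay, with a stated time of 48 h; on this read-out higher numbers stand for weaker inhibition and lower numbers for stronger inhibition. Compound 1 gives 10400 nM, the higher of the two numbers, while compound 2 gives 4500 nM, a gap beyond the usual scatter. Compound 3 returns only a limit of this assay, > 50000 nM, not a number.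

Compound 4, `O=C(NCCNS(=O)(=O)c1ccc(-c2ccccc2Oc2ccc([N+](=O)[O-])c([N+](=O)[O-])c2)s1)Nc1cc(Cl)cc(Cl)c1`, awaits measurement. It differs from compound 1 in one place: 3,4-dinitrophenyl in place of 3,4-dihydroxyphenyl on an oxygen on an aromatic ring. Among the compounds with values here, no pair of measured compounds separated by a single change exists here, so there is no direct precedent for this swap. The step is expected to run toward weaker inhibition, beyond the scatter, as a 2.9-fold higher number from compound 1 to compound 4 (0.46 log units; beyond the scatter). Compound 4 is therefore estimated at 30000 nM, with a range from 8000 nM to 60000 nM.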

Compound 4, half-maximal inhibitory concentration: 2300 nM
Estimate against measurement, compound 4: 13-fold (1.12 log units) above; measured number below the stated range.
By their numbers in this assay, from the lowest: compounds 4 and 2 (each within the scatter of the next); then compound 1. At a limit, above all of these: compound 3.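

In this assay, 3,4-dinitrophenyl in place of 3,4-dihydroxyphenyl on an oxygen on an aromatic ring gives a 4.5-fold lower number from compound 1 to compound 4 (0.66 log units; beyond the scatter). The position therefore keeps its inhibition, and gains some, with a group carrying 0 hydrogen-bond donors, so the donors of 3,4-dihydroxyphenyl are not needed here. Nothing measured here accounts for this step.

Going by these compounds, whether an amine or a carboxylic acid on this ring would serve as well stays open. So does whether the same change would run the same way on compound 2.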